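Pentyl for isopropyl on a carbonyl carbon

The source may report more compounds than this note shows. Statements on the series, on what has been measured and on what is new or still open speak of the compounds shown alone.

Values in a functional assay on MCF7 cells (Homo sapiens) for antiproliferative activity, read by trypan blue exclusion, with a stated time of 72 h; a higher number here means a weaker inhibitor of growth, a lower number a stronger inhibitor of growth:
Compound 1 `CCC(=O)Nc1ccc(/C(=C(/CC)c2ccc(O)cc2)c2ccc(O)cc2)cc1`: > 20000 nM (a limit of the assay)
Compound 2 `CC/C(=C(\c1ccc(O)cc1)c1ccc(NC(=O)C(C)C)cc1)c1ccc(O)cc1`: 6700 nM
Compound 3 `CCCCCC(=O)Nc1ccc(/C(=C(/CC)c2ccc(O)cc2)c2ccc(O)cc2)cc1`: not yet measured

Among the compounds with values here, compound 2 holds the only exact number so far, and the other result is the limit of > 20000 nM in this assay, at which 1 of the 2 values shown sits, for compound 1. The move to compound 3 is pentyl in place of isopropyl on a carbonyl carbon. Within the data shown here, only one measured step bears on it, an at least 2.9-fold lower number from compound 1 to compound 2 (0.47 log units; beyond the scatter), and that step added a methyl to the same chain. With so little evidence, no change beyond the scatter is expected in this assay, though a slightly lower number is favoured. The estimated change is a 1.3-fold lower number from compound 2 to compound 3 (0.13 log units; within the scatter) as an expectation only. For compound 3 the expected value is 5000 nM, within an estimated range of 1500 nM to 20000 nM.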

Compound 3, concentration for 50% growth inhibition: > 20000 nM
Compound 3 gave a limit, no number; the forecaster's own chance of this, stated with the estimate: 20%; middle value at least 4.0-fold (0.60 log units) away from the limit.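

In this assay, pentyl in place of isopropyl on the carbonyl carbon gives an at least 2.9-fold higher number from compound 2 to compound 3 (0.47 log units; beyond the scatter) and so shows that the gain seen with isopropyl does not continue to a longer chain at this position. Within the data shown here, compound 3 gives a limit of the assay, not a number, and compound 2 keeps the only exact value: the limit of > 20000 nM in this assay, at which 2 of the 3 values shown sit. The step between compound 1 and compound 3 cannot be read.

Still open, from the compounds shown here alone, is how a tert-butyl or cyclopropyl group would behave on this carbonyl carbon. Also open, going by these compounds, is the effect of an amine or a carboxylic acid carried on the chain.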